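Cytotoxicity notes: chloro for methyl on compound 2

The compounds below may be only part of what the source reports. "The series", "measured", "known", "first", "only" and "open" are said of these compounds alone.

Of the compounds shown here, three have been tested in a toxicity assay on THP-1 cells (Homo sapiens) for inhibition (on this read-out higher numbers stand for lower toxicity in this test and lower numbers for higher toxicity in this test), and each has given only a limit. Compound 1 `COc1ccc(-c2noc(NC(=O)c3ccc(F)cc3)c2C)cc1` gives > 100000 nM in this assay, a limit of the assay and not a number. Compound 3 `COc1ccc(-c2cnc(NC(=O)c3ccc([N+](=O)[O-])cc3)n2C)cc1` likewise gives > 100000 nM in this assay, again a limit. Compound 2 `Cc1ccccc1-c1cnc(NC(=O)c2ccc(F)cc2)n1C` gives > 50000 nM in this assay, also a limit of the assay. Going by the values given here, compound 2 thus sits at the limit of > 50000 nM in this assay, at which 1 of the 3 values shown sits, whereas the other two results sit at the limit of > 100000 nM in this assay, at which 2 of the 3 values shown sit; with limits only, no ordering among the three can be drawn, and no step between measured compounds is available.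

Compound 4 `Cn1c(-c2ccccc2Cl)cnc1NC(=O)c1ccc(F)cc1` differs from compound 2 by chloro in place of methyl on an aromatic carbon. Among the compounds with values here, the change is small in what it counts, and no measured step bears on it; no step beyond the usual scatter is expected for compound 4 in this assay. The estimate for compound 4 is 60000 nM, between 20000 nM and 200000 nM, most probably reported once more as a limit. This corresponds to an expected step that the limit leaves unreadable from compound 2 to compound 4.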

Compound 4, half-maximal cytotoxic concentration: > 50000 nM
Compound 4: no number, only a limit; the forecaster's own chance of this, stated with the estimate: 85%; the middle value lies beyond the limit too.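

Compound 2 and compound 4 each give only a limit in this assay, so no step can be read for chloro in place of methyl: the limit of > 50000 nM in this assay, at which 2 of the 4 values shown sit.

The compounds shown leave open where any actual cytotoxic concentration lies in this assay and whether 2-methylphenyl and 2-chlorophenyl differ at all.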